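Methyl on the remaining phenol oxygen

A few compounds are considered here, and "the series" means these few. Any claim that something is new, unique, unknown or untested is made for them only; others in the source may bear on it.

Compound 1 `Oc1ccc(/C=C/c2ccccc2O)cc1` gives 21 ug/mL in a functional assay on MCF7 cells (Homo sapiens) for inhibition, read by MTT assay, with a stated time of 2 days; on this read-out higher numbers stand for weaker inhibition and lower numbers for stronger inhibition; of the two compounds measured, compound 2 `COc1ccc(/C=C/c2ccccc2O)cc1` gives 17 ug/mL, so compound 1 has the higher of the two numbers, a difference within the scatter. Among the compounds with values here, the only measured step, a 1.2-fold lower number from compound 1 to compound 2 (0.09 log units; within the scatter), is a methylation of a phenol oxygen. Compound 3 `COc1ccccc1/C=C/c1ccc(O)cc1` differs from compound 1 by methyl in place of hydrogen on an oxygen on an aromatic ring. That step bears directly on this change and was within the scatter, so no step beyond the scatter is expected in this assay. Compound 3 is therefore estimated at 19 ug/mL, range 9 ug/mL to 40 ug/mL. The expected step is a 1.1-fold lower number from compound 1 to compound 3 (0.04 log units; within the scatter).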

Compound 3, half-maximal inhibitory concentration: 19 ug/mL
Compound 3: middle estimate and measured number agree at the digits printed; the range from low to high includes it.
By their numbers in this assay, from the lowest: compounds 2, 3 and 1 (each within the scatter of the next).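

In this assay the change to methoxy at this oxygen gives a 1.1-fold lower number from compound 1 to compound 3 (0.04 log units; within the scatter), so the free hydroxy here is not needed for a number of this size. With a 1.2-fold lower number from compound 1 to compound 2 (0.09 log units; within the scatter), each of the two oxygens of compound 1 has now carried a methyl without a step beyond the scatter. Nothing at hand bears on the reason for this. Open remains whether both oxygens can carry methyl together, and whether an amine in place of either hydroxy, or a longer chain such as propyl on either oxygen, would give a step beyond the scatter.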